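Removing the hydroxy from a compound that shows no inhibition

A few compounds are considered here, and "the series" means these few. Any claim that something is new, unique, unknown or untested is made for them only; others in the source may bear on it.

Compound 1 `COCn1c(CC(O)(COCc2ccccc2)COCc2ccccc2)cc(=O)[nH]c1=O` carries a hydroxy on its side chain. In a functional assay on MIA PaCa-2 cells (Homo sapiens) for antiproliferative activity, read by MTT assay, with a stated time of 72 h (on this read-out higher numbers stand for weaker inhibition and lower numbers for stronger inhibition), compound 1 gives > 100000 nM, a limit of the assay rather than a number. Among the compounds with values here, compound 2 `C[Si](C)(C)CCOCn1c(CC(O)(COCc2ccccc2)COCc2ccccc2)cc(=O)[nH]c1=O` is the one measured neighbour; in this assay compound 2 gives > 100000 nM, also a limit. Hence a step that the two limits leave unreadable from compound 1 to compound 2, with both values at the limit of > 100000 nM in this assay, at which 2 of the 2 values shown sit. Compound 3 `COCn1c(CC(COCc2ccccc2)COCc2ccccc2)cc(=O)[nH]c1=O` differs from compound 1 by hydrogen in place of hydroxy on a saturated chain carbon bound to three saturated chain carbons. Within the data shown here, no measured step touches this hydroxy, so the only guide is the limit of compound 1. Compound 3 is expected to give 150000 nM, somewhere from 50000 nM to 500000 nM. This expected step, a step that the limit leaves unreadable from compound 1 to compound 3, means no change beyond the scatter.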

Compound 3, half-maximal inhibitory concentration: > 100000 nM
Compound 3 was reported as a limit (the forecaster's own chance of this, stated with the estimate: 85%); the middle value does not contradict the limit.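

The step from compound 1 to compound 3 cannot be read, because each of the two compounds gives only a limit and not a number: the limit of > 100000 nM in this assay, at which 3 of the 3 values shown sit.

On these data alone, whether the hydroxy has any bearing on inhibition in this assay stays open.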